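Aryl variation on the piperazine thiocarbamate: a nitro analogue

The source may hold more compounds than are shown below. What is called first, only, known or untested is meant among the compounds shown, and "the series" means these compounds.

The series shares one core and varies only the aryl group on the ring nitrogen. Compound 1 `Nc1nc(N)c2cc(CSC(=S)N3CCN(c4ccc(O)cc4)CC3)ccc2n1` gives 5090 nM in a functional assay on MCF7 cells (Homo sapiens) for antiproliferative activity, read by MTT assay, with a stated time of 72 h; on this read-out lower numbers stand for stronger inhibition and higher numbers for weaker inhibition. Compound 2 `Cc1ccccc1N1CCN(C(=S)SCc2ccc3nc(N)nc(N)c3c2)CC1` gives 4230 nM, and compound 3 `Nc1nc(N)c2cc(CSC(=S)N3CCN(c4ccc(Cl)cc4)CC3)ccc2n1` gives 4880 nM. The three numbers sit close together: the step of a 1.2-fold lower number from compound 1 to compound 2 (0.08 log units; within the scatter) and the step of a 1.2-fold higher number from compound 2 to compound 3 (0.06 log units; within the scatter) both stay inside the usual scatter, as does the step of a 1.0-fold lower number from compound 1 to compound 3 (0.02 log units; within the scatter), so compound 2 cannot be told apart from either neighbour on these numbers.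

Compound 4 `Nc1nc(N)c2cc(CSC(=S)N3CCN(c4ccc([N+](=O)[O-])cc4)CC3)ccc2n1` has not been measured. Relative to compound 2 the change is 4-nitrophenyl in place of 2-methylphenyl on an amine nitrogen in a ring. Within the data shown here, the steps that bear on this change are the two earlier swaps of the aryl group on the same ring nitrogen, from compound 1 to compound 2 and from compound 2 to compound 3, and neither moved the number beyond the scatter. With 4-hydroxyphenyl, 2-methylphenyl and 4-chlorophenyl all giving indistinguishable numbers, the expectation for 4-nitrophenyl is a step of a 1.1-fold higher number from compound 2 to compound 4 (0.03 log units; within the scatter), that is, no movement beyond the scatter. Compound 4 is therefore estimated at 4500 nM, with a range from 2200 nM to 9000 nM.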

Compound 4, half-maximal inhibitory concentration: 1470 nM
The estimate for compound 4 lay 3.1-fold (0.49 log units) above the measured number; the whole stated range lies above it.
By their numbers in this assay, from the lowest: compound 4; then compounds 2, 3 and 1 (each within the scatter of the next).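

In this assay the aryl group on the ring nitrogen proves able to move the number: 4-nitrophenyl in place of 2-methylphenyl gives a 2.9-fold lower number from compound 2 to compound 4 (0.46 log units; beyond the scatter) and the same group stands apart from the other two aryl groups, with nitro in place of chloro giving a 3.3-fold lower number from compound 3 to compound 4 (0.52 log units; beyond the scatter) and nitro in place of hydroxy giving a 3.5-fold lower number from compound 1 to compound 4 (0.54 log units; beyond the scatter) on the same aromatic carbon. The steps are modest, but all three lie beyond the scatter, so compound 4 is the most potent of the four in this read-out, whereas the earlier swaps among 4-hydroxyphenyl, 2-methylphenyl and 4-chlorophenyl had given no sign that this position could separate compounds at all. The data offered here give no measured account of why the nitro group stands apart.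

Whether the lower number belongs to the nitro group alone stays open, since the compounds shown do not tell how a nitrile, a carboxylic acid or an amine would read on the same aromatic carbon. They also leave open how the nitro group would read on another carbon of the phenyl ring.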